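A second methyl on the pyrazole of compound 3

The source may report more compounds than this note shows. Statements on the series, on what has been measured and on what is new or still open speak of the compounds shown alone.

Measured in a functional assay on U2OS cells for antagonist activity at C-X-C chemokine receptor type 3 (Homo sapiens), read by beta-arrestin recruitment (on this read-out lower numbers stand for stronger inhibition and higher numbers for weaker inhibition), so far:
Compound 1, `CCOc1ncc(-c2nc(C(F)(F)F)sc2N2CCN(C(=O)Cn3cnc4ccccc43)[C@H](C)C2)cn1`, gives 49 nM.
Compound 2, `CCOc1ncc(-c2nc(C(F)(F)F)sc2N2CCN(C(=O)Cn3ccc4cnccc43)[C@H](C)C2)cn1`, gives 23 nM.
Compound 3, `CCOc1ncc(-c2nc(C(F)(F)F)sc2N2CCN(C(=O)Cn3nccc3C)[C@H](C)C2)cn1`, gives 162 nM.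

Compound 3 stands highest of the three numbers in this assay: the step of a 3.3-fold higher number from compound 1 to compound 3 (0.52 log units; beyond the scatter) and the step of a 7.0-fold higher number from compound 2 to compound 3 (0.85 log units; beyond the scatter) both run toward weaker inhibition, and the step of a 2.1-fold lower number from compound 1 to compound 2 (0.33 log units; beyond the scatter) is the smallest of the three. All of these steps exchange the whole heteroaryl group that sits on the saturated chain carbon bound to the carbonyl carbon.

Compound 4, `CCOc1ncc(-c2nc(C(F)(F)F)sc2N2CCN(C(=O)Cn3nc(C)cc3C)[C@H](C)C2)cn1`, keeps the pyrazole of compound 3 and differs from it only by methyl in place of hydrogen on an aromatic carbon. Going by the values given here, no measured pair shows a methyl added to an aromatic carbon of this ring, so the measured steps bear on it only loosely: they show that the size and kind of the heteroaryl group matters, while the change here is a single carbon. The expectation is therefore a step of a 1.1-fold lower number from compound 3 to compound 4 (0.03 log units; within the scatter) that stays within the scatter, without a direction that can be read off the data. Compound 4 is estimated at 150 nM, in the range 60 nM to 400 nM.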

Compound 4, half-maximal inhibitory concentration: 87 nM
Estimate against measurement, compound 4: 1.7-fold (0.24 log units) above; measured number inside the range.
By their numbers in this assay, from the lowest: compound 2; then compounds 1, 4 and 3 (each within the scatter of the next, the first and the last beyond it).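

Placing a methyl on this aromatic carbon of the pyrazole, two ring bonds from the ring atom that bears the large group, gives a 1.9-fold lower number from compound 3 to compound 4 (0.27 log units; within the scatter) and so no readable change in this assay: the position accepts this one added carbon, but the data fix no direction for it. The 3,5-dimethyl-1H-pyrazol-1-yl group can also not be told apart from 1H-benzimidazol-1-yl, with a 1.8-fold higher number from compound 1 to compound 4 (0.25 log units; within the scatter) as the step between them, although the 5-methyl-1H-pyrazol-1-yl group of compound 3 stood beyond the scatter from that same group, while a 3.8-fold higher number from compound 2 to compound 4 (0.58 log units; beyond the scatter) shows that the fused group of compound 2 still stands clear of the dimethyl pyrazole. Nothing measured here accounts for any of these steps.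

The compounds shown leave open whether an ethyl, a methoxy or an amino group on this same aromatic carbon would stay within the scatter of compound 3 or move the number clearly. They also leave open whether a pyrazole carrying no methyl at all would hold its place among these numbers.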